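Benzylamine head change on the phenoxy-substituted core

The compounds below may be only part of what the source reports. "The series", "measured", "known", "first", "only" and "open" are said of these compounds alone.

For the measured compounds named here, compound 3 `COc1ccccc1Oc1ccc2c(NCCCNCc3cccc(OC)c3O)ccnc2c1` gives the highest number of the three measured so far in an ADME assay on HepG2 cells (Homo sapiens) for cytotoxicity, read by luminescence, CellTiter-Glo and ATP content, with a stated time of 72 h (on this read-out higher numbers stand for an effect only at larger amounts of compound and lower numbers for an effect already at smaller amounts), at 11200 nM. Compound 1 `COc1ccc(F)cc1CNCCCNc1ccnc2cc(C3CCCCC3)ccc12` gives 2290 nM and compound 2 `COc1ccc(F)cc1CNCCCNc1ccnc2cc(CCC(C)C)ccc12` gives 890 nM. Both of these carry the same benzylamine end as the new compound but differ from compound 3 in the substituent on the shared core as well, so neither pair with compound 3 isolates a single change. Going by the values given here, the one measured step, a 2.6-fold lower number from compound 1 to compound 2 (0.41 log units; beyond the scatter), concerns the core substituent and not the benzylamine end, and so does not bear on the present change. Compound 4 `COc1ccc(F)cc1CNCCCNc1ccnc2cc(Oc3ccccc3OC)ccc12` arises from compound 3 by 5-fluoro-2-methoxyphenyl in place of 2-hydroxy-3-methoxyphenyl on a saturated chain carbon bound to an amine nitrogen. Among the compounds with values here, no measured step isolates this change. Since compounds 1 and 2, which share the new benzylamine end, both sit lower than compound 3, a modest decrease is expected, and the step of a 2.2-fold lower number from compound 3 to compound 4 (0.35 log units; beyond the scatter) is the estimated outcome, with a wide range. For compound 4 the expected value is 5000 nM, between 1500 nM and 16000 nM.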

Compound 4, half-maximal effective concentration: 6400 nM
Beside the measured number, compound 4's estimate is 1.3-fold (0.11 log units) below it; the range from low to high includes it.
By their numbers in this assay, from the lowest: compound 2; then compound 1; then compounds 4 and 3 (each within the scatter of the next).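

In this assay, 5-fluoro-2-methoxyphenyl in place of 2-hydroxy-3-methoxyphenyl on a saturated chain carbon bound to an amine nitrogen gives a 1.8-fold lower number from compound 3 to compound 4 (0.24 log units; within the scatter), so this exchange does not separate the two compounds on the phenoxy-substituted core. With the 5-fluoro-2-methoxybenzyl end held constant, the core substituent gives steps beyond the scatter: 2-methoxyphenoxy in place of isopentyl gives a 7.2-fold higher number from compound 2 to compound 4 (0.86 log units; beyond the scatter), and 2-methoxyphenoxy in place of cyclohexyl gives a 2.8-fold higher number from compound 1 to compound 4 (0.45 log units; beyond the scatter). No supporting measurement bears on the reason for these results.

The compounds shown leave open whether the 2-hydroxy-3-methoxyphenyl end would also stay within the scatter of the 5-fluoro-2-methoxyphenyl end on the isopentyl or cyclohexyl core. They also leave open how an unsubstituted benzyl group or a carboxylic acid at this place would read.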